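The source may hold more compounds than are shown below. What is called first, only, known or untested is meant among the compounds shown, and "the series" means these compounds.

Measured compounds:
Compound 1, `COc1ccc2c(=O)c(/C=C/C(=O)NCc3ccc(F)cc3)coc2c1`, in a functional assay on A549 cells (Homo sapiens) for inhibition, read by MTT assay, with a stated time of 48 h (on this read-out lower numbers stand for stronger inhibition and higher numbers for weaker inhibition), gives only a limit, > 100000 nM.
Compound 2, `O=C(/C=C/c1coc2cc(O)ccc2c1=O)NCc1ccc(F)cc1`, in this assay gives only a limit, > 100000 nM.
Compound 3, `Cc1ccccc1NC(=O)/C=C/c1coc2cc(O)ccc2c1=O`, in this assay gives only a limit, > 100000 nM.

All three measured compounds share one core and differ in two places. From compound 2 to compound 1 the change is methyl in place of hydrogen on an oxygen on an aromatic ring; the step that the two limits leave unreadable from compound 2 to compound 1 cannot be sized, since both values are limits. From compound 2 to compound 3 the change is 2-methylphenyl in place of 4-fluorobenzyl on an amide-type nitrogen, and here too the step that the two limits leave unreadable from compound 2 to compound 3 is not readable. What the three values share is the limit of > 100000 nM in this assay, at which 3 of the 3 values shown sit, so nothing in the set tells which, if any, of these changes moves the read-out.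

Compound 4, `COc1ccc2c(=O)c(/C=C/C(=O)Nc3ccccc3C)coc2c1`, has not yet been measured in this assay. It differs from compound 3 by methyl in place of hydrogen on an oxygen on an aromatic ring, the same change that separates compound 2 from compound 1, with the place described in identical words. Since compound 3 gives only a limit, > 100000 nM, and the same change from compound 2 to compound 1 left both values at the limit, compound 4 is expected to sit at the limit as well, with an expected step that the limit leaves unreadable from compound 3 to compound 4. Compound 4 is accordingly estimated at 150000 nM, with a range from 50000 nM to 500000 nM, and the most likely outcome is that this assay again reports only a limit for compound 4.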

Compound 4, half-maximal inhibitory concentration: 23400 nM
Estimate against measurement, compound 4: 6.4-fold (0.81 log units) above; the whole stated range lies above it.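

With the 2-methylphenyl amide, the change from hydroxy to methoxy gives in this assay an at least 4.2-fold lower number from compound 3 to compound 4 (0.63 log units; beyond the scatter), and with the methoxy group held fixed, the change of amide group gives an at least 4.2-fold lower number from compound 1 to compound 4 (0.63 log units; beyond the scatter). With the 4-fluorobenzyl amide, the same change from hydroxy to methoxy joins two limits, so that step and the other steps between limits cannot be read, and compound 1 goes against any idea that methoxy alone brings a measurable number. The change is thus seen to lower the number on one core only, by a size known only as a minimum, and the compounds neither show that it carries over to the other core nor show that it fails there, since most of the set gives no number to compare: the limit of > 100000 nM in this assay, at which 3 of the 4 values shown sit.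

The compounds shown leave open what a longer chain on that oxygen, such as ethyl or propyl, would do in this assay with the 2-methylphenyl amide. They also leave open whether a plain phenyl or a 4-fluorophenyl on the amide nitrogen would give a measurable number with either hydroxy or methoxy.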